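A few compounds are considered here, and "the series" means these few. Any claim that something is new, unique, unknown or untested is made for them only; others in the source may bear on it.

- Compound 1 `COc1ccc(C(=O)Nc2ccc(C#N)cc2)c(O)c1`: 5430 nM
- Compound 2 `N#Cc1ccc(NC(=O)c2ccc(-c3ccccc3)cc2O)cc1`: 410 nM

For the measured compounds named here, in a functional assay on KG-1 cells (Homo sapiens) for cytotoxicity, read by luminescence and CellTiter-Glo, with a stated time of 3 days (on this read-out lower numbers stand for stronger inhibition and higher numbers for weaker inhibition), compound 2 stands at 410 nM, the lower of the two numbers measured so far, while compound 1 gives 5430 nM. Compound 3 `N#Cc1ccc(NC(=O)c2ccccc2O)cc1` has not yet been measured and departs from compound 2 in one place: hydrogen in place of phenyl on an aromatic carbon. This puts hydrogen in place of phenyl on an aromatic carbon, meta to a hydroxy group.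

Going by the values given here, only one measured step bears on this change. It concerns the same carbon, where phenyl takes the place of methoxy: a 13-fold lower number from compound 1 to compound 2 (1.12 log units; beyond the scatter), a large step beyond the scatter. Among the compounds with values here, compound 3 also lacks the phenyl of compound 2, but it carries hydrogen rather than methoxy, and no measured compound shows what hydrogen does at this carbon. A large step towards a higher number in this assay is therefore expected, of roughly the size seen between compound 1 and compound 2, though this rests on a single pair. The expected change is a 9.8-fold higher number from compound 2 to compound 3 (0.99 log units; beyond the scatter). For compound 3 the estimated value is 4000 nM, with an expected range from 1200 nM to 13000 nM.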

Compound 3, half-maximal inhibitory concentration: 5370 nM
Compound 3: the middle estimate sits 1.3-fold (0.13 log units) below what was measured; low and high end bracket the measured number.
By their numbers in this assay, from the lowest: compound 2; then compounds 3 and 1 (each within the scatter of the next).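

In this assay, taking the phenyl away gives a 13-fold higher number from compound 2 to compound 3 (1.12 log units; beyond the scatter), a large step beyond the scatter, and this shows the effect of phenyl against hydrogen directly rather than against methoxy alone. The comparison of the two small groups at this carbon gives a 1.0-fold lower number from compound 1 to compound 3 (0.00 log units; within the scatter), which lies within the scatter, so hydrogen and methoxy cannot be told apart here and, among the three compounds, only the phenyl of compound 2 sets a carbon substituent apart. No evidence on the origin of this difference is available.

The compounds shown leave open whether the step is specific to phenyl or would also appear with another group at this carbon, such as an amine, a carboxylic acid or a longer chain like butyl. They also leave open whether phenyl would give a step of this size on any other carbon of the shared core.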